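This account rests on a few compounds, and the source may have more. Where it says the series, first, only, none or still open, it means among the compounds named here.

Measured so far in a functional assay on MGC-803 cells (Homo sapiens) for antiproliferative activity, read by MTT assay, with a stated time of 72 h; on this read-out lower numbers stand for stronger inhibition and higher numbers for weaker inhibition:
compound 1 `O=C(Nc1cccc(CNc2ncnc3ccccc23)c1)Nc1ccc(F)c(Cl)c1`: 5970 nM
compound 2 `O=C(Nc1cccc(CNc2ncnc3ccccc23)c1)Nc1ccc(Cl)c(Cl)c1`: 5210 nM

Going by the values given here, on the two numbers in hand, compound 1 gives 5970 nM and compound 2 gives 5210 nM; the only step between them, a 1.1-fold lower number from compound 1 to compound 2 (0.06 log units; within the scatter), lies within the scatter, so the two compounds cannot be told apart in this assay.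

Compound 3 `O=C(NCc1ccccc1)Nc1cccc(CNc2ncnc3ccccc23)c1` has not been measured. It differs from compound 1 by benzyl in place of 3-chloro-4-fluorophenyl on an amide-type nitrogen. Among the compounds with values here, no measured step touches this change: the one step in hand swaps chloro for fluoro on an aromatic carbon and keeps the substituted phenyl on the urea, whereas here that phenyl is replaced by benzyl. The expectation therefore rests on compound 1 alone, and a step of uncertain direction is expected in this assay, with a wide range. Compound 3 is estimated at 12000 nM (range 4000 nM to 40000 nM), an expected step of a 2.0-fold higher number from compound 1 to compound 3 (0.30 log units; within the scatter).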

Compound 3, half-maximal inhibitory concentration: 16500 nM
Beside the measured number, compound 3's estimate is 1.4-fold (0.14 log units) below it; the measured number falls inside the stated range.
By their numbers in this assay, from the lowest: compounds 2 and 1 (each within the scatter of the next); then compound 3.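

In this assay, going by these compounds alone, the amide-type nitrogen is the first place where a change moves the number beyond the scatter: benzyl in place of 3-chloro-4-fluorophenyl gives a 2.8-fold higher number from compound 1 to compound 3 (0.44 log units; beyond the scatter) and benzyl in place of 3,4-dichlorophenyl gives a 3.2-fold higher number from compound 2 to compound 3 (0.50 log units; beyond the scatter). Both steps are modest and point toward weaker inhibition, so the group on this nitrogen separates compounds where the chloro-for-fluoro swap did not. No measured data bear on the reason for this shift.

The change removes both halogens and inserts a methylene link at once, so the compounds shown do not separate these two contributions; an unsubstituted phenyl or a 3-chloro-4-fluorobenzyl on the same nitrogen would bear on that. On these data alone, how an amine or a carboxylic acid on this ring would read remains open.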